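From Trifluoromethyl to Methyl on Compound 1

This account rests on a few compounds, and the source may have more. Where it says the series, first, only, none or still open, it means among the compounds named here.

Among the measured compounds shown here, in a functional assay on the whole organism for inhibition, with Rattus norvegicus as the target (on this read-out lower numbers stand for an effect already at smaller amounts and higher numbers for an effect only at larger amounts of compound), compound 1 (`CC(C)c1ccc(OC(C)(Cc2cccc(C(F)(F)F)c2)C(=O)O)cc1`) gives 5 mg/kg, its only single number, as one further entry for it carries none. Compound 2 (`CC(C)c1ccc(OC(C)(Cc2ccc(Cl)cc2)C(=O)O)cc1`), the other measured compound, gives 1 mg/kg; 1 mg/kg; 1 mg/kg (3 entries), so compound 1 has the higher number of the two and needs a larger dose for the same effect. Compound 3 (`Cc1cccc(CC(C)(Oc2ccc(C(C)C)cc2)C(=O)O)c1`) has methyl in place of trifluoromethyl on an aromatic carbon, meta to a large group: methyl in place of trifluoromethyl on an aromatic carbon. For the measured compounds named here, no two measured compounds differ in this one place alone, so the data offer no direct guide to this exchange. The expected result in this assay is no change at the digits printed from compound 1 to compound 3 (within the scatter), with no shift beyond the usual scatter in either direction. The best anchor is compound 1 at 5 mg/kg. For compound 3 the estimated dose is 5 mg/kg, with an expected range from 1.5 mg/kg to 15 mg/kg.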

Compound 3, dose for half-maximal effect: < 1 mg/kg
Compound 3: a limit, no number; the forecaster's own chance of this, stated with the estimate: 10%; middle value at least 5.0-fold (0.69 log units) away from the limit.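

Putting methyl in place of trifluoromethyl on this aromatic carbon gives an at least 5.0-fold lower number from compound 1 to compound 3 (0.69 log units; beyond the scatter) in this assay. Among the compounds shown here, this is the first direct sign that the group at this position matters for the dose needed in the whole animal, and here the smaller group, with one heavy atom where trifluoromethyl has four, is the better of the two. Compound 3 gives < 1 mg/kg, and the full size of the step stays unknown because this value is a limit of the assay and not a number: the limit of < 1 mg/kg in this assay, at which 1 of the 3 values shown sits.

For the compounds shown here, with only two groups compared at this position, one step cannot show a trend from small to large groups. From the compounds shown here alone, what an ethyl group, a methoxy group or an amine would do on this same carbon remains open, as does the effect of a plain hydrogen there.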